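Coumarin series: substituent opposite the ring oxygen

A few compounds are considered here, and "the series" means these few. Any claim that something is new, unique, unknown or untested is made for them only; others in the source may bear on it.

Compound 1 `CN(C)C(=O)COc1cc(=O)oc2cc(OCc3cccc(Cl)c3)ccc12`, 501 nM; compound 2 `O=c1cc(Nc2ccccc2)c2ccc(OCc3cccc(Cl)c3)cc2o1`, 9770 nM.

Within the data shown here, in an assay on isolated protein (strain Sprague-Dawley) for inhibition of Amine oxidase [flavin-containing] B (Rattus norvegicus), read by spectrophotometry, with a stated time of 5 min (a lower number here means a stronger inhibitor, a higher number a weaker inhibitor), compound 2 stands highest of the two numbers; the only step to it, a 20-fold higher number from compound 1 to compound 2 (1.29 log units; beyond the scatter), is large and beyond the scatter. Compound 3 `O=c1cc(CCl)c2ccc(OCc3cccc(Cl)c3)cc2o1` carries chloromethyl in place of anilino on an aromatic carbon. Among the measured compounds shown here, no measured step exchanges anilino for chloromethyl; the one step at this position shows only that a change here can move the number by a large amount in either sense. The direction for compound 3 is therefore uncertain, and a wide range is expected with a 6.5-fold lower number from compound 2 to compound 3 (0.81 log units; beyond the scatter). For compound 3 the estimate is 1500 nM, between 150 nM and 15000 nM.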

Compound 3, half-maximal inhibitory concentration: 43.7 nM
Estimate against measurement, compound 3: 34-fold (1.54 log units) above, outside the stated range (below it).
By their numbers in this assay, from the lowest: compound 3; then compound 1; then compound 2.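

In this assay chloromethyl opposite the ring oxygen gives the lowest number of the three, with a 220-fold lower number from compound 2 to compound 3 (2.35 log units; beyond the scatter) and an 11-fold lower number from compound 1 to compound 3 (1.06 log units; beyond the scatter) as the two steps to it. The range at this position is thus much wider than the anilino and (dimethylcarbamoyl)methoxy pair alone showed, and the group with no ring and no hydrogen-bond donor or acceptor stands lowest. Nothing measured here speaks to the cause of this drop.

Open, as far as these compounds go, is whether the chlorine itself matters. The compounds shown do not separate chloromethyl from a plain methyl, a hydroxymethyl or an aminomethyl at this position.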